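Chloro for fluoro on the shared core of compound 2

A few compounds are considered here, and "the series" means these few. Any claim that something is new, unique, unknown or untested is made for them only; others in the source may bear on it.

Compound 1 `CCN1C(=O)C(O)(Cc2nnn[nH]2)c2ccccc21` carries an ethyl on the amide nitrogen. In a functional assay on PC-3 cells (Homo sapiens) for antiproliferative activity, read by MTT assay, with a stated time of 48 h (on this read-out higher numbers stand for weaker inhibition and lower numbers for stronger inhibition), compound 1 gives > 100000 nM, which is a limit of the assay rather than a number. Compound 2 `O=C1N(Cc2ccc(Br)cc2)c2ccc(F)cc2C1(O)Cc1nnn[nH]1` carries a bromobenzyl group and a fluoro on the fused ring. In this assay compound 2 gives > 100000 nM, again a limit and not a measured value. On the numbers shown compound 2 stands level with compound 1, because of the limit of > 100000 nM in this assay, at which 2 of the 2 values shown sit. Among the compounds with values here, neither compound shows measurable inhibition, so no step between measured compounds can be sized.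

Compound 3 `O=C1N(Cc2ccc(Br)cc2)c2ccc(Cl)cc2C1(O)Cc1nnn[nH]1` differs from compound 2 by chloro in place of fluoro on an aromatic carbon. With both shown values sitting at the limit there is no measured step to lean on; the step in this assay is expected to be a step that the limit leaves unreadable from compound 2 to compound 3, that is, none beyond the scatter. Compound 3 is accordingly expected to give 150000 nM, with a range of 50000 nM to 500000 nM, and most likely to be reported once more as a limit rather than a number.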

Compound 3, half-maximal inhibitory concentration: 87900 nM
Compound 3: the middle estimate sits 1.7-fold (0.23 log units) above what was measured; low and high end bracket the measured number.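

Within the data shown here, compound 3 gives 87900 nM in this assay, the only actual number among the three values shown, which gives this aromatic carbon of the shared core its first reading inside the measurable range. Chloro in place of fluoro gives an at least 1.1-fold lower number from compound 2 to compound 3 (0.05 log units; that floor lies within the scatter), so what can be read of this change is only a floor and does not by itself separate the two compounds. From the compounds shown here alone, the true size of the step remains unknown because one end of it is not a number: the limit of > 100000 nM in this assay, at which 2 of the 3 values shown sit.

Still open, going by these compounds, is whether a different group on this same aromatic carbon, such as a methoxy or an amine, would shift the number further in either direction, and whether a chloro would read the same with another group on the amide nitrogen. Compound 1 differs from compound 2 and compound 3 in more than one place, so the ethyl and the bromobenzyl group cannot be compared directly, and the part played by the group on the amide nitrogen stays unresolved.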